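Series notes: aryl variation and antiproliferative read-out

The compounds below may be only part of what the source reports. "The series", "measured", "known", "first", "only" and "open" are said of these compounds alone.

Measured so far:
compound 1 `O=c1c2ccccc2[se]n1-c1nnc(-c2ccc(Cl)cc2)s1` — 19500 nM
compound 2 `O=c1c2ccccc2[se]n1-c1nnc(-c2ccc(F)cc2)s1` — 61500 nM
compound 3 `Cc1cccc(-c2nnc(-n3[se]c4ccccc4c3=O)s2)c1` — 19900 nM

In a functional assay on MCF7 cells (Homo sapiens) for antiproliferative activity, read by CCK-8 assay, with a stated time of 48 h (on this read-out lower numbers stand for stronger inhibition and higher numbers for weaker inhibition), compound 3 gives 19900 nM, the second highest of the three numbers. The step of a 1.0-fold higher number from compound 1 to compound 3 (0.01 log units; within the scatter) means the two cannot be told apart on this read-out; the step of a 3.1-fold lower number from compound 2 to compound 3 (0.49 log units; beyond the scatter) is a modest gap. Compound 4 `O=c1c2ccccc2[se]n1-c1nnc(-c2ccccc2Br)s1` is not yet measured. It differs from compound 3 in one place: 2-bromophenyl in place of 3-methylphenyl on an aromatic carbon.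

Within the data shown here, no measured step exchanges a 3-methylphenyl for a 2-bromophenyl, and no measured compound carries bromine. The nearest information is the halogen swap a 3.2-fold higher number from compound 1 to compound 2 (0.50 log units; beyond the scatter), which moved the number by a modest amount, and the pair a 1.0-fold higher number from compound 1 to compound 3 (0.01 log units; within the scatter), which shows chloro and methyl on the aryl group giving numbers within scatter of each other. Going by these compounds, because a 1.0-fold higher number from compound 1 to compound 3 (0.01 log units; within the scatter) shows that kind of exchange leaving the number flat, the expectation for compound 4 in this assay is a step of a 1.0-fold higher number from compound 3 to compound 4 (0.00 log units; within the scatter), no change beyond the scatter, with a broad range since this substitution pattern is untested. Compound 4 is therefore estimated at 20000 nM, between 6000 nM and 65000 nM.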

Compound 4, half-maximal inhibitory concentration: 59400 nM
Beside the measured number, compound 4's estimate is 3.0-fold (0.47 log units) below it; low and high end bracket the measured number.
By their numbers in this assay, from the lowest: compounds 1 and 3 (each within the scatter of the next); then compounds 4 and 2 (each within the scatter of the next).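

In this assay, the flat step seen earlier on this aromatic carbon does not hold for every aryl exchange: 2-bromophenyl gives a 3.0-fold higher number from compound 3 to compound 4 (0.47 log units; beyond the scatter), and the comparison with the chloro compound gives a 3.0-fold higher number from compound 1 to compound 4 (0.48 log units; beyond the scatter), both modest. The step of a 1.0-fold lower number from compound 2 to compound 4 (0.02 log units; within the scatter) puts compound 4 level with the 4-fluorophenyl compound, so the four compounds form two groups, and halogen alone does not sort them: the chloro compound 1 sits with the methyl compound 3, while the fluoro compound 2 sits with the bromo compound 4. Nothing available on these compounds accounts for this split into two groups.

Compound 4 differs from compound 1 in both the halogen and its place on the phenyl ring, so the compounds shown leave open which of the two goes with the modest step, a question that 4-bromophenyl and 2-chlorophenyl groups would separate. Also open, going by these compounds, is how a phenyl group carrying an amine or a carboxylic acid would read on this aromatic carbon, and whether a longer alkyl chain in place of the aryl group would hold the number.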